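Phenylethynyl replacing phenylethenyl: expected lipophilicity

This account rests on a few compounds, and the source may have more. Where it says the series, first, only, none or still open, it means among the compounds named here.

Of the compounds shown here, two carry numbers so far. Compound 1 `O=C(COC(=O)/C=C/c1ccccc1)NCCC[Te]c1ccccc1` in a physicochemical assay for lipophilicity, read by HPLC, measured as octanol-water partition (a higher number here means a more lipophilic compound, a lower number a more polar compound), gives 3.01. Compound 2 `COc1ccc(N(CC(=O)NCCCSc2ccccc2)C(=O)c2ccccc2)cc1`, built on a different core, gives in this assay a value of 3.1; the two numbers lie within the scatter of each other, so neither can be placed ahead of the other. Within the data shown here, no pair of measured compounds differs in a single place, so no measured step is available to lean on.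

Compound 3 `O=C(COC(=O)C#Cc1ccccc1)NCCC[Te]c1ccccc1` is the next member to be measured. Relative to compound 1 the change is 2-phenylethynyl in place of 2-phenylethenyl on a carbonyl carbon. Among the measured compounds shown here, with no comparable measured step, the expectation for this assay is a small shift, downward if anything, and likely to stay within the scatter. Compound 3 is accordingly estimated at 2.8, with a range from 2.4 to 3.2. The expected step of a number 0.21 log units lower from compound 1 to compound 3 (within the scatter) is thus small and not clearly beyond the scatter.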

Compound 3, partition coefficient: 0.9
For compound 3 the middle estimate is 1.90 log units above the measured one; measured number below the stated range.
By their numbers in this assay, from the lowest: compound 3; then compounds 1 and 2 (each within the scatter of the next).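

In this assay, among these compounds, 2-phenylethynyl in place of 2-phenylethenyl on a carbonyl carbon gives a number 2.11 log units lower from compound 1 to compound 3 (beyond the scatter), the first single-place step. This position is therefore not indifferent to the change, even though the leaving and entering groups match in heavy atoms, in the aromatic ring and in hydrogen-bond donors and acceptors, and differ in the count only by a triple bond outside the aromatic ring where a double bond stood. No measurement at hand accounts for the size of this step.

Where a saturated 2-phenylethyl group on the same carbonyl carbon would fall remains open, so this single step cannot separate an effect of the triple bond from one of the double bond. Also open, going by these compounds, is whether the same change gives a step of similar size when sulfur stands in place of tellurium in the core of compound 1.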